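This account rests on a few compounds, and the source may have more. Where it says the series, first, only, none or still open, it means among the compounds named here.

Compound 1 `O=C1c2ccccc2S(=O)(=O)N1CCCCCN1CCN(c2ccc(Cl)cc2)CC1`: 703 nM
Compound 2 `O=C1c2ccccc2S(=O)(=O)N1CCCCCCN1CCN(c2ncccn2)CC1`: 5710 nM

In an assay on HEK293 cells for displacement of a labelled ligand from 5-hydroxytryptamine receptor 6 (Homo sapiens) (a lower number here means a stronger inhibitor, a higher number a weaker inhibitor), compound 1 gives 703 nM, the lower of the two numbers shown. Compound 2 gives 5710 nM in this assay, and the gap between the two lies beyond the scatter. Compound 3 `O=C1c2ccccc2S(=O)(=O)N1CCCCCN1CCN(c2cccc3ccccc23)CC1` differs from compound 1 by naphthalen-1-yl in place of 4-chlorophenyl on an amine nitrogen in a ring. Among the compounds with values here, no pair of measured compounds shows a change of this kind, so the two values are all there is to go on. The expected step is a 3.2-fold lower number from compound 1 to compound 3 (0.50 log units; beyond the scatter), toward a lower number and beyond the scatter. Compound 3 is estimated at 220 nM, with a range from 60 nM to 800 nM.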

Compound 3, inhibition constant: 101 nM
For compound 3 the middle estimate is 2.2-fold (0.34 log units) above the measured one; the range from low to high includes it.
By their numbers in this assay, from the lowest: compound 3; then compound 1; then compound 2.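

In this assay, the group on the amine nitrogen of the ring is shown for the first time to change the result on its own: naphthalen-1-yl in place of 4-chlorophenyl gives a 7.0-fold lower number from compound 1 to compound 3 (0.84 log units; beyond the scatter) in a single-place comparison. A second six-membered aromatic ring of carbon is therefore accepted at this position, though that rests on this one pair. Nothing measured here explains the step. Still open, on these data alone, is whether a naphthalen-2-yl or quinolin-8-yl group would do the same, and whether a longer chain would change the result with naphthalen-1-yl kept in place.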